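Methoxy in place of 1-methyl-1H-pyrazol-4-yl: expected potency

The source may hold more compounds than are shown below. What is called first, only, known or untested is meant among the compounds shown, and "the series" means these compounds.

Compound 1, `Cn1cc(-c2cccc3c2CCC3c2ncc[nH]2)cn1`: > 10000 nM
Compound 2, `CS(=O)(=O)Nc1cccc2c1CCCC2c1ncc[nH]1`: > 10000 nM; > 10000 nM; > 10000 nM (3 entries)
Compound 3, `c1ccc2c(c1)CCCC2c1ncc[nH]1`: 791 nM

In a functional assay on CHO cells for agonist activity at Alpha-1B adrenergic receptor (Homo sapiens), read by FLIPR and calcium flux (on this read-out higher numbers stand for an effect only at larger amounts of compound and lower numbers for an effect already at smaller amounts), compound 1 gives only a limit, (the limit of > 10000 nM in this assay, at which 1 of the 3 values shown sits), and no number. Compound 2 likewise returns only a limit in this assay, in all three runs. For the measured compounds named here, compound 3 is the one compound of the set with a measured number in this assay, 791 nM.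

Compound 4, `COc1cccc2c1CCC2c1ncc[nH]1`, is not yet measured. It differs from compound 1 by methoxy in place of 1-methyl-1H-pyrazol-4-yl on an aromatic carbon. Going by the values given here, no measured pair spans this change, so the step from compound 1 is open. The methoxy compound is expected to fall nearer compound 3 than compound 1, an estimated step of an at least 3.3-fold lower number from compound 1 to compound 4 (0.52 log units; beyond the scatter). Compound 4 is expected at 3000 nM, within 600 nM to 15000 nM, with a fair chance of another limit.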

Compound 4, half-maximal effective concentration: > 10000 nM
Compound 4 was reported as a limit; the forecaster's own chance of this, stated with the estimate: 40%; at least 3.3-fold (0.52 log units) between middle value and limit.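

Compound 1 and compound 4 both stand only as limits in this assay, so no step can be read between them: the limit of > 10000 nM in this assay, at which 2 of the 4 values shown sit.

Going by these compounds, whether methoxy in place of 1-methyl-1H-pyrazol-4-yl changes potency at all, and by how much, stays open.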